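From butyl to pentyl: extending the chain of compound 3

The source may report more compounds than this note shows. Statements on the series, on what has been measured and on what is new or still open speak of the compounds shown alone.

In a functional assay on MCF7 cells (Homo sapiens) for antiproliferative activity, with a stated time of 5 days (on this read-out lower numbers stand for stronger inhibition and higher numbers for weaker inhibition), compound 3 (`CCCCc1ccc2[nH]c(-c3ccc(C(F)(F)F)cc3)c(C=O)c2c1`) gives 66 nM. Compound 2 (`CCCCc1ccc2[nH]c(-c3ccc(CC)cc3)c(C=O)c2c1`) gives 58 nM. Placing trifluoromethyl where ethyl sat on an aromatic carbon produces a 1.1-fold higher number from compound 2 to compound 3 (0.06 log units; within the scatter), so these two compounds cannot be told apart. Compound 1 (`CCCCCc1ccc2[nH]c(-c3ccc(OC)cc3)c(C=O)c2c1`) gives 20 nM, a clearly lower number than either of them.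

Compound 4 (`CCCCCc1ccc2[nH]c(-c3ccc(C(F)(F)F)cc3)c(C=O)c2c1`) departs from compound 3 through (methyl in place of hydrogen on a saturated chain carbon, four bonds along the chain from an aromatic carbon). This is methyl in place of hydrogen on a saturated chain carbon, four bonds along the chain from an aromatic carbon, and it turns the butyl chain into a pentyl chain.

Within the data shown here, no measured step isolates this change. The only one available, a 1.1-fold higher number from compound 2 to compound 3 (0.06 log units; within the scatter), concerns a different part of the molecule and says nothing direct about the chain. Compound 1 already carries the pentyl chain and gives 20 nM, but it also has methoxy where compound 3 has trifluoromethyl, so its lower number cannot be credited to the chain alone. That gives only weak support for a modest move towards lower numbers, and the expected change is a 1.7-fold lower number from compound 3 to compound 4 (0.22 log units; within the scatter). For compound 4 the estimated value is 40 nM, with an expected range from 16 nM to 95 nM.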

Compound 4, half-maximal inhibitory concentration: 67 nM
For compound 4 the middle estimate is 1.7-fold (0.22 log units) below the measured one; measured number inside the range.
By their numbers in this assay, from the lowest: compound 1; then compounds 2, 3 and 4 (each within the scatter of the next).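

In this assay, among these compounds, extending the butyl chain of compound 3 to the pentyl chain of compound 4 gives a 1.0-fold higher number from compound 3 to compound 4 (0.01 log units; within the scatter), so at this chain position the added methyl leaves the two compounds indistinguishable, a comparison no earlier pair could offer. With the pentyl chain now held constant, a second single-place comparison becomes available: exchanging methoxy for trifluoromethyl gives a 3.4-fold higher number from compound 1 to compound 4 (0.53 log units; beyond the scatter), which ties the lower number of compound 1 to its methoxy group rather than to its chain, at least within this pair. The data shown offer no independent measurement that explains either result.

Whether the chain makes as little difference when methoxy sits on the aromatic carbon remains open, as a butyl partner for compound 1 is not among the compounds shown. Also open, going by these compounds, is how a longer chain such as hexyl, a chain ending in an amine, or a carboxylic acid in place of trifluoromethyl would behave on this read-out.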